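Aryl swap on the triazole of the lactone series

A few compounds are considered here, and "the series" means these few. Any claim that something is new, unique, unknown or untested is made for them only; others in the source may bear on it.

Measured so far:
compound 1 `Cc1ccc(-c2cn(C/C=C3\OC(=O)C(OCc4ccccc4)=C3OCc3ccccc3)nn2)cc1` — in a functional assay on PC-3 cells (Homo sapiens) for antiproliferative activity, read by MTT assay, with a stated time of 24 h (on this read-out higher numbers stand for weaker inhibition and lower numbers for stronger inhibition), a limit only, > 100000 nM
compound 2 `O=C1O/C(=C\Cn2cc(-c3ccccn3)nn2)C(OCc2ccccc2)=C1OCc1ccccc1` — in this assay a limit only, > 100000 nM

Both values shown are limits of the assay rather than numbers. Where compound 2 stands is therefore fixed only by the limit of > 100000 nM in this assay, at which 2 of the 2 values shown sit. Within the data shown here, the single measured step, a step that the two limits leave unreadable from compound 1 to compound 2, cannot be read in size or direction, since both ends are limits.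

Compound 3 `O=C1O/C(=C\Cn2cc(-c3ccccc3)nn2)C(OCc2ccccc2)=C1OCc1ccccc1` carries the change (phenyl in place of pyridin-2-yl on an aromatic carbon). Among the measured compounds shown here, no measured step bears on this change: the one step available is unreadable, and nothing else shows what replacing pyridin-2-yl by phenyl does here. With both neighbours at the limit, the expectation is that compound 3 also reaches no measurable inhibition, and the expected step is a step that the limit leaves unreadable from compound 2 to compound 3, i.e. none beyond the scatter. Compound 3 is estimated at 150000 nM, within 50000 nM to 500000 nM, most likely reported again as a limit.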

Compound 3, half-maximal inhibitory concentration: > 100000 nM
Compound 3 gave a limit, no number (the forecaster's own chance of this, stated with the estimate: 75%); the middle value lies beyond the limit too.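

No step among compound 1, compound 2 and compound 3 can be read in this assay, since all three values are limits and not numbers: the limit of > 100000 nM in this assay, at which 3 of the 3 values shown sit.

The compounds shown leave open whether any group on the triazole gives a measurable value in this assay.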